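This account rests on a few compounds, and the source may have more. Where it says the series, first, only, none or still open, it means among the compounds named here.

Measured compounds:
compound 1 `CC1(C)S[C@@H]2/C(=C\C(=O)c3ccc(C(F)(F)F)cc3)C(=O)N2[C@H]1C(=O)OC(c1ccccc1)c1ccccc1`, 26700 nM
compound 2 `CC1(C)S[C@@H]2/C(=C\C(=O)c3ccc([N+](=O)[O-])cc3)C(=O)N2[C@H]1C(=O)OC(c1ccccc1)c1ccccc1`, 50300 nM

Both compounds share one core and differ only in the group on the aromatic ring. For the measured compounds named here, in a functional assay on A-375 cells (Homo sapiens) for cytotoxicity, read by MTT assay, with a stated time of 48 h (on this read-out higher numbers stand for weaker inhibition and lower numbers for stronger inhibition), compound 2 gives the highest of the two numbers; its only neighbour is compound 1, and the step of a 1.9-fold higher number from compound 1 to compound 2 (0.28 log units; within the scatter) lies within the scatter, so the two values cannot be told apart. Compound 3 `CCOC(=O)/C=C1/C(=O)N2[C@@H]1SC(C)(C)[C@@H]2C(=O)OC(c1ccccc1)c1ccccc1` is the next compound. The change from compound 2 to compound 3 is ethoxy in place of 4-nitrophenyl on a carbonyl carbon: the whole aromatic part is removed and a short chain takes its place. Going by the values given here, no measured step bears on this change; the single step of a 1.9-fold higher number from compound 1 to compound 2 (0.28 log units; within the scatter) swaps one group on the aromatic ring for another and does not touch the part that is now replaced. With both measured values lying close together at weak inhibition, the expectation for compound 3 in this assay is a number in the same region, and the step of a 1.3-fold lower number from compound 2 to compound 3 (0.10 log units; within the scatter) is estimated as no change beyond the scatter, with wide uncertainty. The estimate for compound 3 is 40000 nM, within a range from 10000 nM to 160000 nM.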

Compound 3, half-maximal inhibitory concentration: 7000 nM
Compound 3: the middle estimate sits 5.7-fold (0.76 log units) above what was measured, and the stated range ends above it.
By their numbers in this assay, from the lowest: compound 3; then compounds 1 and 2 (each within the scatter of the next).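

The carbonyl carbon carrying the double-bonded chain carbon turns out to be a place where a change can shift the number beyond the scatter: in this assay, ethoxy in place of 4-nitrophenyl gives a 7.2-fold lower number from compound 2 to compound 3 (0.86 log units; beyond the scatter) and ethoxy in place of 4-(trifluoromethyl)phenyl gives a 3.8-fold lower number from compound 1 to compound 3 (0.58 log units; beyond the scatter). The earlier pair, by contrast, differed only in the group carried on the aromatic ring and gave a 1.9-fold higher number from compound 1 to compound 2 (0.28 log units; within the scatter); so replacing the whole aromatic part has an effect on this read-out that swapping that group did not show, and compound 3 is the strongest inhibitor of the three. Nothing available here explains why the shorter ethoxy group goes with the lower number.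

With a single non-aromatic group at this place, the compounds shown cannot separate the removal of the aromatic ring from the arrival of the ethoxy oxygen. From the compounds shown here alone, whether the trend would continue with a methyl group, follow a longer chain such as butoxy, or change with an amine or a plain phenyl on the same carbonyl carbon remains open.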